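A few compounds are considered here, and "the series" means these few. Any claim that something is new, unique, unknown or untested is made for them only; others in the source may bear on it.

Among the measured compounds shown here, in an ADME assay for permeability, using PAMPA, with a stated time of 4 h, at pH 7.4 (a higher number here means that the compound crosses the layer faster, a lower number that the compound crosses the layer more slowly), compound 2 (`CN(C)CCCCN(C[C@H]1Cc2ncccc2CN1)[C@H]1CCCc2cccnc21`) gives 240 nm/s, the higher of the two numbers so far, against 68 nm/s for compound 1 (`NC/C=C\CN(C[C@H]1Cc2ncccc2CN1)[C@H]1CCCc2cccnc21`). Compound 3 (`CCN(CC)CCCCN(C[C@H]1Cc2ncccc2CN1)[C@H]1CCCc2cccnc21`) differs from compound 2 in one place: diethylamino in place of dimethylamino on a saturated chain carbon, four bonds along the chain from an amine nitrogen. For the measured compounds named here, the only measured step, a 3.5-fold higher number from compound 1 to compound 2 (0.55 log units; beyond the scatter), is a different change, and no measured pair exchanges dimethylamino for diethylamino, so it offers only a loose guide. The expected step is small, a 1.3-fold higher number from compound 2 to compound 3 (0.10 log units; within the scatter), with no shift beyond the scatter anticipated. For compound 3 the estimate is 300 nm/s, with an expected range of 130 nm/s to 650 nm/s.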

Compound 3, apparent permeability: 240 nm/s
Estimate against measurement, compound 3: 1.3-fold (0.10 log units) above; measured number inside the range.
By their numbers in this assay, from the lowest: compound 1; then compounds 2 and 3 (each within the scatter of the next).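

In this assay, diethylamino in place of dimethylamino on a saturated chain carbon, four bonds along the chain from an amine nitrogen, gives no change at the digits printed from compound 2 to compound 3 (within the scatter), so this position takes a group of 5 heavy atoms in place of one of 3 without a shift beyond the scatter. The gap to the aminopropenyl compound stands unaltered, with 3-(diethylamino)propyl in place of 3-aminoprop-1-en-1-yl giving a 3.5-fold higher number from compound 1 to compound 3 (0.55 log units; beyond the scatter). Nothing shown gives a reason for either step. Still open, as far as these compounds go, is whether a pyrrolidine in place of diethylamino, or a longer chain carrying it, would hold the number in this assay.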